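The source may report more compounds than this note shows. Statements on the series, on what has been measured and on what is new or still open speak of the compounds shown alone.

Compound 1 `CCCCCCCCNC(=O)/C=C/c1c(/C=C/c2ccc(OC)cc2)cc(OC)cc1OC`: 8060 nM
Compound 2 `CCC(C)NC(=O)/C=C/c1c(/C=C/c2ccc(OC)cc2)cc(OC)cc1OC`: 4380 nM
Compound 3 `COc1ccc(/C=C/c2cc(OC)cc(OC)c2/C=C/C(=O)N2CCCCC2)cc1`: 9750 nM

These three compounds share one core and differ only in the group attached to the amide carbonyl; all were tested in a functional assay on B16-F10 cells (Mus musculus) for inhibition, read by MTT assay, with a stated time of 48 h; a lower number here means a stronger inhibitor, a higher number a weaker inhibitor. Among them compound 3 gives the highest number: against compound 1 the gap lies within the scatter (a 1.2-fold higher number from compound 1 to compound 3 (0.08 log units; within the scatter)), while against compound 2 it is modest (a 2.2-fold higher number from compound 2 to compound 3 (0.35 log units; beyond the scatter)). Compound 4 `COc1ccc(/C=C/c2cc(OC)cc(OC)c2/C=C/C(=O)N2CCC(c3ccccc3)CC2)cc1` has not yet been measured. It differs from compound 3 in a single place: phenyl in place of hydrogen on a saturated ring carbon. Within the data shown here, no measured step touches this part of the molecule. The known steps all exchange the whole group on the carbonyl carbon, and each of them was small: a 1.8-fold lower number from compound 1 to compound 2 (0.26 log units; within the scatter), a 1.2-fold higher number from compound 1 to compound 3 (0.08 log units; within the scatter) and a 2.2-fold higher number from compound 2 to compound 3 (0.35 log units; beyond the scatter). Since every change at this end of the molecule so far has shifted the result only slightly, the added phenyl is expected to leave the number close to that of compound 3, with no step beyond the scatter in either direction. The expected step is a 1.1-fold lower number from compound 3 to compound 4 (0.03 log units; within the scatter). The estimate for compound 4 in this assay is 9000 nM, with a range from 3000 nM to 27000 nM.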

Compound 4, half-maximal inhibitory concentration: 9180 nM
The estimate for compound 4 lay 1.0-fold (0.01 log units) below the measured number; the measured number falls inside the stated range.
By their numbers in this assay, from the lowest: compounds 2, 1, 4 and 3 (each within the scatter of the next, the first and the last beyond it).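

In this assay, among these compounds, compound 4 gives the first view of a change inside the six-membered non-aromatic ring, rather than an exchange of the whole group on the carbonyl carbon, and phenyl in place of hydrogen on this saturated ring carbon, three ring bonds from the ring nitrogen, gives a 1.1-fold lower number from compound 3 to compound 4 (0.03 log units; within the scatter) in the same assay, so a whole aromatic ring can be added at this position with no step that stands out from the scatter. The 4-phenylpiperidin-1-yl group also stays close to the long open chain, with a 1.1-fold higher number from compound 1 to compound 4 (0.06 log units; within the scatter) as the step from octylamino, while the step from (sec-butyl)amino, a 2.1-fold higher number from compound 2 to compound 4 (0.32 log units; beyond the scatter), is modest and about the same size as a 2.2-fold higher number from compound 2 to compound 3 (0.35 log units; beyond the scatter) for the plain piperidin-1-yl group. No measurement at hand accounts for how little the added phenyl matters here.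

Whether this position accepts any group or only plain phenyl remains open, since a hydroxyl, an amine, a carboxylic acid or a benzyl group on the same ring carbon does not appear among these compounds. The compounds shown also keep the methoxy groups of the shared core unchanged, so how the number responds to changes at that end of the molecule stays unknown.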